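Swapping the chain end of compound 2 for ethyl

A few compounds are considered here, and "the series" means these few. Any claim that something is new, unique, unknown or untested is made for them only; others in the source may bear on it.

In a functional assay on A549 cells (Homo sapiens) for antiproliferative activity, read by MTT assay, with a stated time of 48 h (on this read-out lower numbers stand for stronger inhibition and higher numbers for weaker inhibition), compound 2 `CN1CCN(CCn2c(N)c(-c3nc4ccccc4[nH]3)c3nc(C#N)c(C#N)nc32)CC1` gives 40500 nM, and compound 3 `CCN(CC)CCCn1c(N)c(-c2nc3ccccc3[nH]2)c2nc(C#N)c(C#N)nc21` gives 25300 nM. Compound 1 `CCN(CC)CCn1c(N)c(-c2nc3ccccc3[nH]2)c2nc(C#N)c(C#N)nc21` gives > 50000 nM, which is a limit of the assay. Only compound 2 and compound 3 therefore have exact numbers, and these lie within the scatter of each other.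

Compound 4 `CCCCn1c(N)c(-c2nc3ccccc3[nH]2)c2nc(C#N)c(C#N)nc21` has ethyl in place of 4-methylpiperazin-1-yl, turning the 2-(4-methylpiperazin-1-yl)ethyl group into butyl: ethyl in place of 4-methylpiperazin-1-yl on a saturated chain carbon, two bonds along the chain from an aromatic nitrogen.

The measured steps at this place show nothing beyond the scatter: an at least 1.2-fold lower number from compound 1 to compound 2 (0.09 log units; that floor lies within the scatter), an at least 1.9-fold lower number from compound 1 to compound 3 (0.29 log units; that floor lies within the scatter) and a 1.6-fold lower number from compound 2 to compound 3 (0.20 log units; within the scatter). None of them puts ethyl there, so they guide only loosely. No step beyond the scatter is expected, and the estimated change is a 1.4-fold lower number from compound 2 to compound 4 (0.13 log units; within the scatter). Compound 4 is expected at 30000 nM, within a range of 10000 nM to 50000 nM.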

Compound 4, half-maximal inhibitory concentration: > 50000 nM
Compound 4 was reported as a limit; the forecaster's own chance of this, stated with the estimate: 35%; middle value at least 1.6-fold (0.22 log units) away from the limit.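

In this assay compound 4 gives > 50000 nM, which is a limit. Butyl at this position therefore yields an at least 1.2-fold higher number from compound 2 to compound 4 (0.09 log units; that floor lies within the scatter) and an at least 1.9-fold higher number from compound 3 to compound 4 (0.29 log units; that floor lies within the scatter), so neither step shows a real loss when the amine at the chain end gives way to plain carbon. The step between compound 1 and compound 4 cannot be read, since both are reported as limits: the limit of > 50000 nM in this assay, at which 2 of the 4 values shown sit.

Going by these compounds, what a morpholin-4-yl group or a carboxylic acid at the chain end would give in this assay stays open, as does a longer chain such as hexyl.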